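The compounds below may be only part of what the source reports. "The series", "measured", "known", "first", "only" and "open" are said of these compounds alone.

Compound 1 `O=c1[nH]c(=O)n([C@H]2C[C@H](O)[C@@H](CO)O2)cc1-c1cn(-c2ccc(OC(F)(F)F)cc2)nn1` – 37000 nM
Compound 2 `O=c1[nH]c(=O)n([C@H]2C[C@H](O)[C@@H](CO)O2)cc1-c1cnnn1-c1c(F)cccc1F` – 5000 nM

Going by the values given here, both values come from an ADME assay on HeLa cells (Homo sapiens) for cytotoxicity, read by cell counting, with a stated time of 4 days (a lower number here means a stronger inhibitor, a higher number a weaker inhibitor), and are the only measurements available so far. Of the two, compound 2 has the lower number, and its gap to compound 1 lies beyond the usual scatter.

Compound 3 `O=c1[nH]c(=O)n([C@H]2C[C@H](O)[C@@H](CO)O2)cc1-c1cnnn1-c1ccc(Br)cc1` has not yet been measured. It is compound 2 with one structural change (4-bromophenyl in place of 2,6-difluorophenyl on an aromatic nitrogen): 4-bromophenyl in place of 2,6-difluorophenyl on an aromatic nitrogen. The rest of the molecule stays the same.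

Among the compounds with values here, no two measured compounds differ in only one place, so the data give no direct guide to this swap. The only yardstick is the span from compound 2 at 5000 nM to compound 1 at 37000 nM and a result inside that span seems most likely. A modest move toward a higher number, and so a weaker effect, is expected (a 2.4-fold higher number from compound 2 to compound 3 (0.38 log units; beyond the scatter)) but this expectation is uncertain. For compound 3 the estimated value is 12000 nM with an expected range of 4000 nM to 35000 nM in this assay when it is tested.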

Compound 3, half-maximal inhibitory concentration: 8000 nM
For compound 3 the middle estimate is 1.5-fold (0.18 log units) above the measured one; measured number inside the range.
By their numbers in this assay, from the lowest: compounds 2 and 3 (each within the scatter of the next); then compound 1.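

Placing 4-bromophenyl where 2,6-difluorophenyl stood on the aromatic nitrogen gives, in this assay, a 1.6-fold higher number from compound 2 to compound 3 (0.20 log units; within the scatter) and so no real separation between the pair. Going by these compounds alone, this is the only direct comparison at this position, and it shows that a phenyl ring with two fluorine atoms and a phenyl ring with one bromine atom cannot be told apart here, even though the halogen and its place on the ring both differ. Compound 1 differs from both in more than one place and adds nothing to this reading, and no measurement to hand accounts for the likeness of the pair.

Both groups compared at this nitrogen are halogen-bearing phenyl rings, so the result says nothing yet about a phenyl ring carrying a methoxy group, an amine or a carboxylic acid, or about a saturated ring such as cyclohexyl in the same place. Also open, on these data alone, is how much of the shared result depends on the halogens and how much on the phenyl ring itself, which an unsubstituted phenyl group at this position would help to separate.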